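This account rests on a few compounds, and the source may have more. Where it says the series, first, only, none or still open, it means among the compounds named here.

Measured compounds:
compound 1, `C=CCc1cc(-c2sc(NC(=O)C(C)(C)C)nc2C)nn1C(=O)Nc1ccc(OC)cc1`, with an assay on cells with Cystic fibrosis transmembrane conductance regulator variant F508del (Homo sapiens) as the target, read by fluorescence, with stated times of 24 h and 30 min (on this read-out lower numbers stand for an effect already at smaller amounts and higher numbers for an effect only at larger amounts of compound), giving for compound 1 933 nM
compound 2, `CN(C)CCN1CCN(c2nc(-c3ccccn3)nc3c2CN(S(=O)(=O)c2ccccc2)CC3)CC1`, with this assay giving for compound 2 100000 nM

Compound 2 stands at the top of these two numbers; compound 1 gives the lower value, and the gap between the two lies well beyond the usual scatter, so compound 2 is the weaker of the pair in this assay.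

Compound 3 `CN(C)CCN1CCN(c2nc(-c3ccccn3)nc3c2CN(Cc2ccc(F)cc2)CC3)CC1` is built from compound 2 by one change: 4-fluorobenzyl in place of phenylsulfonyl on an amine nitrogen in a ring. Among the compounds with values here, no measured pair shows this change, so there is no direct precedent for its size or direction. With compound 2 already at the weak end, the step is estimated as a 2.0-fold lower number from compound 2 to compound 3 (0.30 log units; within the scatter), a modest shift toward a lower number that may well stay inside the scatter. Compound 3 is therefore expected to give 50000 nM, within the range 10000 nM to 100000 nM.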

Compound 3, half-maximal effective concentration: 100000 nM
Estimate against measurement, compound 3: 2.0-fold (0.30 log units) below, within the range that was stated.
By their numbers in this assay, from the lowest: compound 1; then compounds 2 and 3 (each within the scatter of the next).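

In this assay, putting 4-fluorobenzyl in place of phenylsulfonyl on this amine nitrogen in a ring gives no change at the digits printed from compound 2 to compound 3 (within the scatter). The hydrogen-bond acceptors counted on phenylsulfonyl are absent from 4-fluorobenzyl, while the six-membered aromatic ring of carbon remains, and this exchange leaves no visible mark on the read-out. Nothing available explains this result.

From the compounds shown here alone, because compound 2 and compound 3 share the same high number, it remains open whether any group on this nitrogen can bring the number down, for example an acetyl group, a plain hydrogen giving the free amine, or a longer chain ending in a carboxylic acid. Compound 1 differs from both in more than one place, so it cannot settle that question.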